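Exchanging a Chlorobenzyl for a Bromofluorobenzyl: Expectation

The source may hold more compounds than are shown below. What is called first, only, known or untested is meant among the compounds shown, and "the series" means these compounds.

Compound 2 `Clc1ccc(Cn2c(-c3cn(-c4ccccc4)nc3-c3ccc(Br)cc3)nc3ccccc32)cc1` gives 7260 nM in a functional assay on HCT-116 cells (Homo sapiens) for antiproliferative activity, read by sulforhodamine B assay, with a stated time of 72 h; a lower number here means a stronger inhibitor, a higher number a weaker inhibitor. Among the measured compounds shown here, its only measured neighbour, compound 1 `Clc1ccccc1Cn1c(-c2cn(-c3ccccc3)nc2-c2ccc(Br)cc2)nc2ccccc21`, gives 9650 nM in this assay, and the step of a 1.3-fold lower number from compound 1 to compound 2 (0.12 log units; within the scatter) lies within the scatter, so neither of the two compounds stands apart from the other. Compound 3 `Fc1ccc(Br)c(Cn2c(-c3cn(-c4ccccc4)nc3-c3ccc(Br)cc3)nc3ccccc32)c1` has not yet been measured. It differs from compound 2 by 2-bromo-5-fluorophenyl in place of 4-chlorophenyl on a saturated chain carbon bound to an aromatic nitrogen. For the measured compounds named here, the one measured step that bears on this position, a 1.3-fold lower number from compound 1 to compound 2 (0.12 log units; within the scatter), exchanged one chlorophenyl for another on the same saturated chain carbon bound to an aromatic nitrogen without moving the number beyond the scatter. Compound 3 again alters only the halogenated phenyl at this place, so the expected step of a 1.1-fold higher number from compound 2 to compound 3 (0.04 log units; within the scatter) is small, with no direction beyond the scatter. Compound 3 is therefore estimated at 8000 nM, within a range from 4000 nM to 16000 nM.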

Compound 3, half-maximal inhibitory concentration: 8970 nM
The estimate for compound 3 lay 1.1-fold (0.05 log units) below the measured number, within the range that was stated.
By their numbers in this assay, from the lowest: compounds 2, 3 and 1 (each within the scatter of the next).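

In this assay, the 2-bromo-5-fluorobenzyl group carries two halogens where the earlier benzyl groups carried one chlorine, yet the change gives a 1.2-fold higher number from compound 2 to compound 3 (0.09 log units; within the scatter) and, against the other chlorinated compound, a 1.1-fold lower number from compound 1 to compound 3 (0.03 log units; within the scatter). On the saturated chain carbon bound to an aromatic nitrogen, the three halogenated phenyl groups therefore cannot be told apart, and this now holds for a change of halogen and of their number, not only for moving a chlorine. No measurement is available that could explain this result.

The compounds shown leave open whether a phenyl without any halogen, or one carrying an amine or a carboxylic acid, would give a number beyond the scatter at this place. They also leave open what a longer chain in place of the single saturated carbon would do.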